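The source may hold more compounds than are shown below. What is called first, only, known or untested is meant among the compounds shown, and "the series" means these compounds.

Measured compounds:
compound 1 `CC(C)CC/N=C(\NC#N)Nc1cccnc1` — 20 mg/kg
compound 2 `N#CN/C(=N\C1CC1)Nc1cccnc1` — 20 mg/kg

In a functional assay on the whole organism (blood, strain Wistar-Okamoto) with Rattus norvegicus as the target, with a stated time of 5 days (a lower number here means that less compound is needed, a higher number that more compound is needed for the effect), compound 2 gives 20 mg/kg, level with compound 1 at the digits shown. Compound 3 `CCCC(C)(C)/N=C(\NC#N)Nc1cccnc1` has not yet been tested. It differs from compound 2 by 1,1-dimethylbutyl in place of cyclopropyl on a double-bonded nitrogen. Among the measured compounds shown here, one measured step bears on this change: no change at the digits printed from compound 1 to compound 2 (within the scatter). That step exchanged one acyclic chain for the cyclopropyl on the same double-bonded nitrogen without moving the minimum effective dose beyond the scatter. Compound 3 is therefore expected to stay close to compound 2, with a step of no change at the digits printed from compound 2 to compound 3 (within the scatter) in this assay. The estimate for compound 3 is 20 mg/kg, ranging from 10 mg/kg to 40 mg/kg.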

Compound 3, minimum effective dose: 1 mg/kg
Compound 3: middle estimate off by 20-fold (1.30 log units), on the high side, and the stated range ends above it.
By their numbers in this assay, from the lowest: compound 3; then compounds 1 and 2 (each within the scatter of the next).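

At this position, on a double-bonded nitrogen, the group is not interchangeable after all: compound 1 and compound 2 stood level in this assay, yet 1,1-dimethylbutyl brings a 20-fold lower number from compound 2 to compound 3 (1.30 log units; beyond the scatter) and a 20-fold lower number from compound 1 to compound 3 (1.30 log units; beyond the scatter). Since isopentyl is also acyclic, having an open chain in place of the cyclopropyl ring is not enough to give this shift. Nothing available explains the shift. The compounds shown leave open whether the branching of 1,1-dimethylbutyl or its length matters, a question that a tert-butyl group or a straight hexyl chain on the same nitrogen would separate.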